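This account rests on a few compounds, and the source may have more. Where it says the series, first, only, none or still open, it means among the compounds named here.

Measured values in an ADME assay on HepG2 cells (Homo sapiens) for cytotoxicity, read by MTT assay, with a stated time of 24 h; on this read-out higher numbers stand for lower toxicity in this test and lower numbers for higher toxicity in this test: compound 1 `CC(C)=CCC1=C(OCc2cn(C3CCN(C(=O)OC(C)(C)C)CC3)nn2)C(=O)c2ccccc2C1=O` gives 136000 nM. Compound 2 `CC(C)=CCC1=C(OCc2cn(-c3cccnc3)nn2)C(=O)c2ccccc2C1=O` gives 1030000 nM. Compound 3 `CC(C)=CCC1=C(OCc2cn(-c3cccc(F)c3)nn2)C(=O)c2ccccc2C1=O` gives 265000 nM.

Compound 2 stands highest of the three numbers, so it is the least toxic here. The closest is compound 3, reached by a 3.9-fold lower number from compound 2 to compound 3 (0.59 log units; beyond the scatter); compound 1 lies further off, as its value shows.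

Compound 4 `CC(C)=CCC1=C(OCc2cn(-c3ccc(C#N)cc3)nn2)C(=O)c2ccccc2C1=O` differs from compound 2 by 4-cyanophenyl in place of pyridin-3-yl on an aromatic nitrogen. For the measured compounds named here, only one measured step bears on this: the exchange of the same aromatic group on the same ring nitrogen from compound 2 to compound 3, which was a modest drop. A drop of similar size is expected in this assay, namely a 2.9-fold lower number from compound 2 to compound 4 (0.47 log units; beyond the scatter). Compound 4 is therefore estimated at 350000 nM, with a range from 120000 nM to 1000000 nM.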

Compound 4, half-maximal cytotoxic concentration: 707000 nM
For compound 4 the middle estimate is 2.0-fold (0.31 log units) below the measured one; measured number inside the range.
By their numbers in this assay, from the lowest: compounds 1 and 3 (each within the scatter of the next); then compounds 4 and 2 (each within the scatter of the next).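

In this assay the change from pyridin-3-yl to 4-cyanophenyl gives a 1.5-fold lower number from compound 2 to compound 4 (0.16 log units; within the scatter) while the change from 3-fluorophenyl to 4-cyanophenyl gives a 2.7-fold higher number from compound 3 to compound 4 (0.43 log units; beyond the scatter) and so the group on this aromatic nitrogen can change the number without the pyridine ring nitrogen. A carbon-only aromatic ring here therefore does not by itself go with a lower number, and compound 3 goes against any such rule. Nothing available explains the gap between the two carbon-only rings.
Still open, as far as these compounds go, is how an amine or a carboxylic acid in place of the nitrile would read. A simple unsubstituted phenyl ring would also show how much the nitrile and the fluorine each contribute.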